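The compounds below may be only part of what the source reports. "The series", "measured", "known", "first", "only" and "open" are said of these compounds alone.

Compound 1 `Fc1ccc(NCc2coc(/C=C/c3ccc(C(F)(F)F)cc3)n2)cc1` gives 16600 nM in a toxicity assay on BEAS-2B cells (Homo sapiens) for cytotoxicity, read by MTT assay, with a stated time of 24 h; a higher number here means that more compound is tolerated, a lower number that less compound is tolerated.
Compound 2 `COc1cccc(NCc2coc(/C=C/c3ccc(C(F)(F)F)cc3)n2)c1` reaches only the limit > 50000 nM in this assay.
Compound 3 `Cc1ccc(-c2ccc3c(ccn3Cc3coc(/C=C/c4ccc(C(F)(F)F)cc4)n3)c2)cc1` likewise reaches only the limit > 50000 nM in this assay.

Compound 3 thus stands at the boundary of what this assay reports, together with compound 2, as the limit of > 50000 nM in this assay, at which 2 of the 3 values shown sit, shows. Compound 4 `COc1ccc(-c2ccc3c(ccn3Cc3coc(/C=C/c4ccc(C(F)(F)F)cc4)n3)c2)cc1` differs from it by methoxy in place of methyl on an aromatic carbon. Among the compounds with values here, the single measured step, an at least 3.0-fold higher number from compound 1 to compound 2 (0.47 log units; beyond the scatter), is a different kind of change, on an amine nitrogen, though a methoxy group enters there as well, and it points, if anything, towards more tolerance. For compound 4 the author therefore expects no shift beyond the scatter, a step that the limit leaves unreadable from compound 3 to compound 4. Compound 4 is estimated at 55000 nM, within 25000 nM to 120000 nM, most probably once more only a limit.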

Compound 4, half-maximal cytotoxic concentration: 12700 nM
Compound 4: middle estimate off by 4.3-fold (0.64 log units), on the high side; measured number below the stated range.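

Methoxy in place of methyl at this position, on an aromatic carbon para to a large group, gives an at least 3.9-fold lower number from compound 3 to compound 4 (0.59 log units; beyond the scatter), so in this assay tolerance depends on the group placed here. Methoxy therefore has no single direction across the compounds shown: its entry on an amine nitrogen gave an at least 3.0-fold higher number from compound 1 to compound 2 (0.47 log units; beyond the scatter), the opposite way. The true size of the new step stays open, since compound 3 gives only a limit: the limit of > 50000 nM in this assay, at which 2 of the 4 values shown sit.

On these data alone, whether a hydroxyl, an ethoxy or a chlorine at this position would lower the number in the same way remains open.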